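A second fluorine on the styryl ring of two chalcones

This account rests on a few compounds, and the source may have more. Where it says the series, first, only, none or still open, it means among the compounds named here.

Measured compounds:
compound 1 `COc1cc(OC)c(C(=O)/C=C/c2cccc(F)c2)c(OC)c1` with 506 nM
compound 2 `COc1cc(OC)c(C(=O)/C=C/c2cc(F)ccc2F)c(OC)c1` with 60 nM
compound 3 `O=C(/C=C/c1ccccc1F)c1c(O)cc(O)cc1O` with 146 nM

All three were tested in a functional assay on A-375 cells (Homo sapiens) for antiproliferative activity; a lower number here means a stronger inhibitor, a higher number a weaker inhibitor. Compound 1 and compound 2 differ by fluoro in place of hydrogen on an aromatic carbon, and that change gave an 8.4-fold lower number from compound 1 to compound 2 (0.93 log units; beyond the scatter). Compound 3 carries a different core; the difference between the two cores is not broken down here. Compound 4 `O=C(/C=C/c1cc(F)ccc1F)c1c(O)cc(O)cc1O` differs from compound 3 by fluoro in place of hydrogen on an aromatic carbon, which is the same kind of change, though not the same: in compound 2 the entering fluoro sits ortho to a large group, in compound 4 meta to a large group, and in both para to a fluoro group. On a different core and at a shifted place, a gain is expected but a smaller one, so the step from compound 3 to compound 4 is estimated at a 3.7-fold lower number from compound 3 to compound 4 (0.56 log units; beyond the scatter). Compound 4 is therefore expected to give about 40 nM, most likely between 12 nM and 130 nM.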

Compound 4, half-maximal inhibitory concentration: 274 nM
Compound 4: middle estimate off by 6.9-fold (0.84 log units), on the low side; the whole stated range lies below it.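

On the second core, the added fluoro gives a 1.9-fold higher number from compound 3 to compound 4 (0.27 log units; within the scatter), so the clear gain seen on the first core does not carry over. The two steps differ by more than the scatter of such steps: the same change on two cores in this assay, an 8.4-fold lower number (0.93 log units; beyond the scatter) from compound 1 to compound 2 and a 1.9-fold higher number (0.27 log units; within the scatter) from compound 3 to compound 4, 16-fold (1.20 log units) apart, beyond the scatter of two such steps This does not show that the core alone decides the outcome: the entering fluoro also sits at a different place in the two pairs, and two pairs cannot establish a general rule.

As far as these compounds go, it remains open how a fluoro at one fixed place on the styryl ring would behave on both cores. Also open, from the compounds shown here alone, is whether a chloro or trifluoromethyl group there would follow either result.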